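Benzyl in place of cyclohexenylmethyl on a benzimidazole amine

The source may report more compounds than this note shows. Statements on the series, on what has been measured and on what is new or still open speak of the compounds shown alone.

Of the compounds shown here, three share one core and have been tested in an assay on isolated protein for inhibition of matrix metalloproteinase-9 (Mus musculus); on this read-out lower numbers stand for stronger inhibition and higher numbers for weaker inhibition. Compound 1 `NCc1nc2cc(NCc3ccccc3OCc3ccccc3)ccc2[nH]1` gives 13000 nM; 13000 nM; 13000 nM (3 entries) across three entries. Compound 2 `NCc1nc2cc(NC(=O)/C=C/c3c(F)cccc3F)ccc2[nH]1` gives 75000 nM, and compound 3 `NCc1nc2cc(NCC3CC=CCC3)ccc2[nH]1` gives 92000 nM. Of the two single numbers, compound 3 has the larger one, though compound 2 lies within the usual scatter of it, so the two cannot be ordered; compound 1 adds a further entry with three readings rather than one.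

Compound 4 `NCc1nc2cc(NCc3ccccc3)ccc2[nH]1` differs from compound 3 by phenyl in place of cyclohex-3-en-1-yl on a saturated chain carbon bound to a nitrogen on an aromatic ring. For the measured compounds named here, no comparable step has been measured, so the expectation rests on compound 3 alone, with a modest gain expected because compound 1, also carrying a phenyl on that chain carbon, gives 13000 nM; 13000 nM; 13000 nM (3 entries). Compound 4 is estimated at 40000 nM, between 10000 nM and 150000 nM, with a 2.3-fold lower number from compound 3 to compound 4 (0.36 log units; beyond the scatter) expected to run toward stronger inhibition.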

Compound 4, half-maximal inhibitory concentration: 195000 nM
Beside the measured number, compound 4's estimate is 4.9-fold (0.69 log units) below it, outside the stated range (above it).
By their numbers in this assay, from the lowest: compounds 2 and 3 (each within the scatter of the next); then compound 4.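

At this position, replacing the non-aromatic ring with an aromatic one of the same size does not strengthen inhibition: the step is a 2.1-fold higher number from compound 3 to compound 4 (0.33 log units; beyond the scatter), toward weaker inhibition. A phenyl on this chain carbon therefore does not by itself bring the lower number of compound 1 13000 nM; 13000 nM; 13000 nM (3 entries), whose phenyl also carries a benzyloxy group. Nothing available explains the step.

Going by these compounds, what remains open is whether a smaller ether such as methoxy on the phenyl of compound 4 would recover inhibition. On these data alone, the effect of a saturated cyclohexyl ring or a longer chain at this position also remains open.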